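Replacing a dichlorophenyl amide with a pyridyl amide

The source may report more compounds than this note shows. Statements on the series, on what has been measured and on what is new or still open speak of the compounds shown alone.

Measured compounds:
Compound 1, `COc1ccc(C(=O)Nc2cccc(Cl)c2Cl)cc1OC1CCCC1`: > 200000 nM
Compound 2, `COc1ccc(C(=O)Nc2ccccc2C(F)(F)F)cc1OC1CCCC1`: 3100 nM
Compound 3, `COc1ccc(C(=O)Nc2c(F)cccc2F)cc1OC`: 900 nM

All three compounds were tested in an assay on isolated protein for inhibition of phosphodiesterase 4A (Sus scrofa); on this read-out higher numbers stand for weaker inhibition and lower numbers for stronger inhibition. Compound 1 gives only a limit in this assay, > 200000 nM, so its true value is not known, only that it lies at the edge of what the assay reports; this is the limit of > 200000 nM in this assay, at which 1 of the 3 values shown sits. Compound 2 gives a number in this assay, 3100 nM, and compound 3 gives 900 nM. For the measured compounds named here, compound 2 and compound 3 differ in more than one place from compound 1 and from each other, so no single step between them can be drawn; their values simply show that amides of this kind can reach measurable inhibition.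

Compound 4, `COc1ccc(C(=O)Nc2cccnc2)cc1OC1CCCC1`, has not yet been measured. It differs from compound 1 in one place: pyridin-3-yl in place of 2,3-dichlorophenyl on an amide-type nitrogen. Because compound 1 sits at the limit of > 200000 nM in this assay, at which 1 of the 3 values shown sits, any measurable value for compound 4 would mean a step toward stronger inhibition. The step of an at least 10-fold lower number from compound 1 to compound 4 (1.00 log units; beyond the scatter) is expected to be toward stronger inhibition, though the size is uncertain. Compound 4 is estimated at 20000 nM, with a range from 3000 nM to 200000 nM.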

Compound 4, half-maximal inhibitory concentration: 550 nM
For compound 4 the middle estimate is 36-fold (1.56 log units) above the measured one; measured number outside the range, below it.
By their numbers in this assay, from the lowest: compounds 4 and 3 (each within the scatter of the next); then compound 2. At a limit, above all of these: compound 1.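

In this assay, pyridin-3-yl in place of 2,3-dichlorophenyl on an amide-type nitrogen gives an at least 360-fold lower number from compound 1 to compound 4 (2.56 log units; beyond the scatter), so this one place can decide between a value at the assay's limit and a clear number while the rest of compound 1 stays unchanged. The change removes both chlorines and brings in a ring nitrogen, and a single pair of compounds cannot separate these two parts of the swap. The true size of the step stays unknown because compound 1 gives a limit rather than a number: the limit of > 200000 nM in this assay, at which 1 of the 4 values shown sits.

Still open, going by these compounds, is whether plain phenyl, with neither chlorine nor ring nitrogen, would sit nearer compound 1 or compound 4. Also open, on these data alone, is whether pyridin-2-yl or pyridin-4-yl would give a value like that of compound 4.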